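A few compounds are considered here, and "the series" means these few. Any claim that something is new, unique, unknown or untested is made for them only; others in the source may bear on it.

Compound 1 `COc1cc(OC)c(C(=O)/C=C/c2cn(-c3ccccc3)nc2-c2ccsc2)c(OC)c1`: in a functional assay on Huh-7 cells (Homo sapiens) for inhibition, read by sulforhodamine B assay, with a stated time of 72 h (a lower number here means a stronger inhibitor, a higher number a weaker inhibitor), compound 1 gives 6100 nM.
Compound 2 `COc1ccc(C(=O)/C=C/c2cn(-c3ccccc3)nc2-c2ccsc2)c(OC)c1OC`: in this assay compound 2 gives 4200 nM.
Compound 3 `O=C(/C=C/c1cn(-c2ccccc2)nc1-c1cccnc1)c1ccsc1`: in this assay compound 3 gives 1700 nM.

Of the three measured compounds, compound 3 gives the lowest number in this assay; compound 2 lies nearest to it with a higher number beyond the scatter, and compound 1 lies furthest, also beyond the scatter. Compound 4 `O=C(/C=C/c1cn(-c2ccccc2)nc1-c1cccnc1)c1c[nH]c2ccccc12` is not yet measured. It differs from compound 3 in one place: 1H-indol-3-yl in place of thiophen-3-yl on a carbonyl carbon. For the measured compounds named here, no measured pair shows such a change on the carbonyl carbon, so there is no step in this assay to lean on, and the expectation rests on the shared core of compound 3 alone. A step of modest size is expected, more likely towards a lower number than a higher one, but possibly within the scatter. The step from compound 3 to compound 4 is estimated at a 1.4-fold lower number from compound 3 to compound 4 (0.15 log units; within the scatter). Compound 4 is therefore expected to give about 1200 nM in this assay, with a likely range from 300 nM to 5000 nM.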

Compound 4, half-maximal inhibitory concentration: 3200 nM
Estimate against measurement, compound 4: 2.7-fold (0.43 log units) below; low and high end bracket the measured number.
By their numbers in this assay, from the lowest: compounds 3, 4, 2 and 1 (each within the scatter of the next, the first and the last beyond it).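

Placing 1H-indol-3-yl in place of thiophen-3-yl on the carbonyl carbon gives a 1.9-fold higher number from compound 3 to compound 4 (0.27 log units; within the scatter) in this assay. For the compounds shown here, this is the first reading of a change at this position, and it shows that the number stays within the usual scatter when a six-membered aromatic ring of carbon only and a hydrogen-bond donor enter together with the five-membered aromatic ring. No measurement at hand accounts for this result.

The compounds shown do not separate the contribution of that six-membered ring from that of the hydrogen-bond donor, as the two enter only together in 1H-indol-3-yl. They also leave open how a naphthyl group, an amine or a carboxylic acid on this carbonyl carbon would read in this assay.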